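Pyrazole carbamates: hydroxymethyl in place of the diethylamide

The compounds below may be only part of what the source reports. "The series", "measured", "known", "first", "only" and "open" are said of these compounds alone.

Measured so far:
compound 1, `CCN(CC)C(=O)c1cc(-c2cccc(OC(=O)NC3CCCCC3)c2)n(-c2ccccc2)n1`: 448 nM
compound 2, `CCOC(=O)c1cc(-c2cccc(OC(=O)NC3CCCCC3)c2)nn1-c1ccccc1`: 539 nM

Both compounds were run in an assay on isolated protein for inhibition of Fatty-acid amide hydrolase 1 (Homo sapiens), read by fluorescence, with a stated time of 30 min; a lower number here means a stronger inhibitor, a higher number a weaker inhibitor. Compound 1 has the lowest number of the two, but compound 2 sits within the scatter of it, so the two cannot be told apart on these numbers. Among the compounds with values here, no pair among the measured compounds differs in a single place, so no step size has been measured.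

Compound 3, `O=C(NC1CCCCC1)Oc1cccc(-c2cc(CO)nn2-c2ccccc2)c1`, is yet to be measured in this assay. It is derived from compound 1 by hydroxymethyl in place of diethylcarbamoyl on an aromatic carbon. Within the data shown here, with no measured step to lean on, the expectation rests on the change alone: the group entering is much smaller than the group leaving, and a shift beyond the scatter toward a higher number is thought somewhat more likely than no shift, though a result within the scatter remains possible. From compound 1 to compound 3 the expected step is a 1.9-fold higher number from compound 1 to compound 3 (0.28 log units; within the scatter). Compound 3 is estimated at 850 nM, within a range from 250 nM to 2800 nM.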

Compound 3, half-maximal inhibitory concentration: 462 nM
Beside the measured number, compound 3's estimate is 1.8-fold (0.26 log units) above it, and the stated range covers the measured number.
By their numbers in this assay, from the lowest: compounds 1, 3 and 2 (each within the scatter of the next).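

In this assay, hydroxymethyl in place of diethylcarbamoyl on an aromatic carbon of the five-membered aromatic ring with 2 nitrogen gives a 1.0-fold higher number from compound 1 to compound 3 (0.01 log units; within the scatter). Within the data shown here, this is the first step measured at this position, and it shows that a group of 7 heavy atoms with no hydrogen-bond donor can give way to one of 2 heavy atoms with a hydrogen-bond donor without a shift that can be told from the scatter. No measurement available here bears on why the two compounds cannot be separated.

Still open, from the compounds shown here alone, is whether this position stays as undemanding with a carboxylic acid, an aminomethyl group or a longer chain such as hydroxypropyl. Going by these compounds, it is equally open whether a methoxymethyl group, which has no hydroxyl hydrogen, would fall within the scatter of compound 3.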